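Benzamide series: aryl swap on the thiourea side chain

A few compounds are considered here, and "the series" means these few. Any claim that something is new, unique, unknown or untested is made for them only; others in the source may bear on it.

Measured so far in a functional assay on MDA-MB-231 cells (Homo sapiens) for cytotoxicity, read by MTT assay, with a stated time of 72 h; on this read-out lower numbers stand for stronger inhibition and higher numbers for weaker inhibition:
compound 1 `Nc1ccccc1NC(=O)c1ccc(NC(=S)NCc2cncc(Br)c2)cc1` gives 39000 nM
compound 2 `Nc1ccccc1NC(=O)c1ccc(NC(=O)NCc2ccc(Cl)nc2)cc1` gives 34000 nM
compound 3 `Nc1ccccc1NC(=O)c1ccc(CNC(=O)c2cc3cccnc3[nH]2)cc1` reports only a limit, > 100000 nM

Two compounds give numbers in this assay and one gives a limit. Compound 1 holds the higher of the two numbers, but compound 2 sits so close that the pair lies within the scatter, and no order can be drawn between them. Compound 3 stands at the limit; the limit itself is the limit of > 100000 nM in this assay, at which 1 of the 3 values shown sits, and is not a number. Among the measured compounds shown here, compound 3 also carries a different linker to its bicyclic fragment, so its two values with compound 1 show only that one is a number and the other a limit.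

The next compound, compound 4 `Nc1ccccc1NC(=O)c1ccc(NC(=S)NCc2cccc(F)c2)cc1`, keeps the thiourea of compound 1 and changes only the aryl group: 3-fluorophenyl in place of 5-bromopyridin-3-yl on a saturated chain carbon bound to an amide-type nitrogen.

For the measured compounds named here, no step between measured compounds involves this position, so there is nothing to scale the change by. The expectation is that the step in this assay stays small, with no direction that can be called beyond the scatter. The step of a 1.1-fold lower number from compound 1 to compound 4 (0.05 log units; within the scatter) is expected to fall within the scatter. Compound 4 is estimated at 35000 nM, with a range from 12000 nM to 100000 nM.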

Compound 4, half-maximal inhibitory concentration: 74000 nM
For compound 4 the middle estimate is 2.1-fold (0.33 log units) below the measured one; measured number inside the range.
By their numbers in this assay, from the lowest: compounds 2, 1 and 4 (each within the scatter of the next, the first and the last beyond it). At a limit, above all of these: compound 3.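

Working notes on the aryl position: the thiourea is held constant, and in this assay this position gives its first readable step, a 1.9-fold higher number from compound 1 to compound 4 (0.28 log units; within the scatter), so on these two compounds the swap of aryl group is not separated from repeat scatter. The change from 5-bromopyridin-3-yl to 3-fluorophenyl replaces the ring nitrogen with carbon and the bromine with fluorine at the same time, and the hydrogen-bond acceptor count of the group falls with it, yet this combined change gives no step beyond the scatter. No measurement shown gives a cause for this result or bears on either part of the change alone.

The two parts of the swap remain unseparated: 3-bromophenyl or 5-fluoropyridin-3-yl on the same saturated chain carbon would each change only one of them. Also open, going by these compounds, is how the read-out responds to groups of another kind on this ring, such as an amine or a carboxylic acid, and to a longer chain in place of the single carbon that carries the aryl group.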